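Chloro to Methyl on the Benzoyl Ring: an Untested Analogue

The source may hold more compounds than are shown below. What is called first, only, known or untested is meant among the compounds shown, and "the series" means these compounds.

Compound 1 `COc1cc2ncnc(NNC(=S)NC(=O)c3ccccc3Cl)c2cc1OC` was examined in a functional assay on KB cells (Homo sapiens) for cytotoxicity, read by MTT assay, with a stated time of 72 h (a lower number here means a stronger inhibitor, a higher number a weaker inhibitor), and in that test compound 1 gives 3560 nM. Going by the values given here, this is the only plain number available for the series, so compound 1 is the sole fixed point from which any expectation can be built. Compound 2 `COc1ccccc1C(=O)NC(=S)NNc1ncnc2ccccc12` was run in the same test, and there compound 2 gives > 50000 nM, which is a limit of the assay rather than a measured number (the limit of > 50000 nM in this assay, at which 1 of the 2 values shown sits).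

Compound 3 `COc1cc2ncnc(NNC(=S)NC(=O)c3ccccc3C)c2cc1OC` has not yet been measured. It differs from compound 1 by a single exchange methyl in place of chloro on an aromatic carbon: one heavy atom leaves and one heavy atom enters, both without ring, donor or acceptor. Among the compounds with values here, no measured pair in this set shows what such an exchange does, so the prediction rests on the small size of the change alone. The step from compound 1 to compound 3 is expected to be a 1.4-fold higher number from compound 1 to compound 3 (0.15 log units; within the scatter), that is, at or near the edge of the usual scatter, leaning toward a weaker inhibitor. Compound 3 is therefore estimated at 5000 nM, with a plausible range from 1500 nM to 20000 nM.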

Compound 3, half-maximal inhibitory concentration: 11400 nM
Estimate against measurement, compound 3: 2.3-fold (0.36 log units) below; the range from low to high includes it.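

The exchange of 2-chlorophenyl for 2-methylphenyl gives this series its first measured step in this assay, namely a 3.2-fold higher number from compound 1 to compound 3 (0.51 log units; beyond the scatter), and so shows that this ring place responds to what sits on it. The earlier compounds shown here could not show this, as they differ from each other in more than one place. Even an exchange of one heavy atom for another, with no ring, hydrogen-bond donor or hydrogen-bond acceptor entering or leaving, is enough to separate the two compounds, with chloro on the side of the stronger inhibitor, yet nothing measured here explains that difference.

Going by these compounds, what remains open is whether chloro is unusual at this place or methyl is simply a poor fit there, a question that bromo, fluoro, trifluoromethyl or an amine on the same aromatic carbon could help to settle. On these data alone, it is also open whether the same exchange would give a step of similar size on another core, as this single pair of compounds in a single cell test cannot establish a general rule.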